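A few compounds are considered here, and "the series" means these few. Any claim that something is new, unique, unknown or untested is made for them only; others in the source may bear on it.

In a functional assay on U-937 cells (Homo sapiens) for antagonist activity, read by calcium flux (on this read-out lower numbers stand for stronger inhibition and higher numbers for weaker inhibition), three compounds sharing a core have been measured so far. Compound 1 `COc1ccc(CCCCCCCCOc2ccc(C[S+]([O-])c3ccccc3)nc2/C=C/C(=O)O)cc1` gives 280 nM, compound 2 `COc1ccc(CCCCCCCCOc2ccc(C[S+]([O-])c3cccc(NS(=O)(=O)c4ccccc4)c3)nc2/C=C/C(=O)O)cc1` gives 150 nM, and compound 3 `COc1ccc(CCCCCCCCOc2ccc(C[S+]([O-])c3cccc(N)c3)nc2/C=C/C(=O)O)cc1` gives 74 nM. Compound 3 therefore has the lowest number of the three, and its gaps to both others lie beyond the usual scatter.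

The next compound, compound 4 `Nc1cccc([S+]([O-])Cc2ccc(OCCCCCCCCc3ccccc3)c(/C=C/C(=O)O)n2)c1`, differs from compound 3 in one place: hydrogen in place of methoxy on an aromatic carbon. In words, hydrogen takes the place of methoxy on an aromatic carbon, para to a large group.

Among the compounds with values here, no measured step tests this change, since all three measured compounds carry the methoxy group. The measured steps were made elsewhere in the molecule, so they offer only a rough guide to size. The step of a 1.9-fold lower number from compound 1 to compound 2 (0.27 log units; within the scatter) is within the scatter, while a 3.8-fold lower number from compound 1 to compound 3 (0.58 log units; beyond the scatter) and a 2.0-fold lower number from compound 2 to compound 3 (0.31 log units; beyond the scatter) are both modest. With nothing larger than a 3.8-fold lower number from compound 1 to compound 3 (0.58 log units; beyond the scatter) seen so far, a modest change is expected here too, and its direction is uncertain, with only a slight lean towards a higher number. The estimated step is a 1.3-fold higher number from compound 3 to compound 4 (0.11 log units; within the scatter). For compound 4 the estimate is 95 nM, with an expected range from 35 nM to 250 nM.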

Compound 4, half-maximal inhibitory concentration: 160 nM
For compound 4 the middle estimate is 1.7-fold (0.23 log units) below the measured one; the range from low to high includes it.
By their numbers in this assay, from the lowest: compound 3; then compounds 2, 4 and 1 (each within the scatter of the next).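

In this assay, replacing the methoxy group with hydrogen, which turns the 4-methoxyphenyl group into a plain phenyl group, gives a 2.2-fold higher number from compound 3 to compound 4 (0.33 log units; beyond the scatter). Within the data shown here, this is the first direct test of this position, since the earlier compounds all carried the methoxy group and their steps came from changes elsewhere in the molecule. The step is modest but lies beyond the usual scatter, so in this pair the methoxy group goes with the stronger inhibition, and nothing available explains why this is so.

Going by these compounds, this rests on a single pair, so it remains open whether the same swap would shift the number similarly in compound 1 or compound 2, which differ from compound 3 on the other aromatic ring. Also open, on these data alone, is how other groups on this aromatic carbon would compare with methoxy and hydrogen, such as a hydroxyl group, an ethoxy group, or a chlorine atom, and whether any of them would give a lower number than the methoxy group does.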